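The source may report more compounds than this note shows. Statements on the series, on what has been measured and on what is new or still open speak of the compounds shown alone.

Measured compounds:
compound 1, `O=C1CCCN1Cc1c(Br)c(O)c(O)c(Br)c1Br`, with 18500 nM in a functional assay; a lower number here means a stronger inhibitor, a higher number a weaker inhibitor
compound 2, `COCc1c(Br)c(O)c(O)c(Br)c1Br`, with 15500 nM in this assay

Going by the values given here, compound 2 sits at the bottom of these two numbers, but the only step recorded, a 1.2-fold lower number from compound 1 to compound 2 (0.08 log units; within the scatter), is within the scatter, so the two values are not told apart. Compound 3, `O=Cc1c(Br)c(O)c(O)c(Br)c1Br`, differs from compound 2 in one place: formyl in place of methoxymethyl on an aromatic carbon. Among the compounds with values here, the single measured step exchanged one group for another on a saturated chain carbon bound to an aromatic carbon and changed nothing beyond the scatter; it does not touch the exchange of methoxymethyl for formyl directly on the aromatic carbon, so no step of the same kind is available for comparison. With the shared core otherwise unchanged, the step of a 1.0-fold lower number from compound 2 to compound 3 (0.01 log units; within the scatter) is expected to stay within the scatter. Compound 3 is therefore estimated to give 15000 nM in this assay, within a range from 5000 nM to 45000 nM.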

Compound 3, half-maximal inhibitory concentration: 24700 nM
Estimate against measurement, compound 3: 1.6-fold (0.22 log units) below, within the range that was stated.
By their numbers in this assay, from the lowest: compounds 2, 1 and 3 (each within the scatter of the next).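

In this assay, placing formyl in place of methoxymethyl gives a 1.6-fold higher number from compound 2 to compound 3 (0.20 log units; within the scatter) on the aromatic carbon itself, ortho to two bromo groups and para to a hydroxy group. The earlier step changed only what was bound to the saturated chain carbon, whereas this one removes that chain carbon and puts a carbonyl directly on the aromatic carbon, and compound 2 and compound 3 are still not told apart. No measurement shown accounts for this result.

From the compounds shown here alone, whether an amine, a carboxylic acid or a longer chain on this aromatic carbon would move the number beyond the scatter remains open. Also open, going by these compounds, is how the number would respond if a methoxy group stood in place of a hydroxy group, or a chlorine atom in place of a bromo group, elsewhere on the shared core.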